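A few compounds are considered here, and "the series" means these few. Any claim that something is new, unique, unknown or untested is made for them only; others in the source may bear on it.

The series shares one core, seen in compound 1 `COc1nc(N)nc2c1c(-c1ccc3oc(N)nc3c1)nn2C(C)C`, compound 2 `CC(C)n1nc(-c2ccc3oc(N)nc3c2)c2c(Cl)nc(N)nc21` and compound 3 `CC(C)n1nc(-c2ccc3oc(N)nc3c2)c2c(Br)nc(N)nc21`, which differ only in the group on the aromatic carbon that compound 4 `CC(C)n1nc(-c2ccc3oc(N)nc3c2)c2c(N)nc(N)nc21` also varies. In an ADME assay on cells (Hepatocyte, Homo sapiens) for metabolic stability, read by LC-MS, with a stated time of 90 min, tested at 1 uM (on this read-out higher numbers stand for fast clearance and lower numbers for slow clearance), compound 1 is recorded as "not determined" (no result reported). In this assay, among the measured compounds shown here, compound 2 gives 11 uL/min, while compound 3 gives 55 uL/min, the higher of the two reported numbers; the single measured step, a 5.0-fold higher number from compound 2 to compound 3 (0.70 log units; beyond the scatter), shows that a change at this position can move the read-out clearly beyond the scatter.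

Compound 4 carries amino in place of bromo on an aromatic carbon. For the measured compounds named here, no measured step pairs a halogen with an amino group, so the bromo-to-chloro step only indicates the scale that a single change at this carbon has produced, not its direction here. Compound 4 is therefore expected to land at 20 uL/min, with a likely range from 6 uL/min to 60 uL/min. The step of a 2.8-fold lower number from compound 3 to compound 4 (0.44 log units; beyond the scatter) is thus estimated to be modest and downward, but with wide uncertainty.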

Compound 4, intrinsic clearance in a liver preparation (reported as CLH), per the amount of preparation that the assay uses: < 5 uL/min
Compound 4 was reported as a limit (the forecaster's own chance of this, stated with the estimate: 10%); middle value at least 4.0-fold (0.60 log units) away from the limit.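

The amino group settles what the opening could only estimate: at this carbon, next to the ring nitrogen, it moves the read-out downward from both halogens. In this assay, compound 4 is reported only as a limit, not as a number: the limit of < 5 uL/min in this assay, at which 1 of the 4 values shown sits. Amino in place of bromo gives an at least 11-fold lower number from compound 3 to compound 4 (1.04 log units; beyond the scatter), and amino in place of chloro gives an at least 2.2-fold lower number from compound 2 to compound 4 (0.34 log units; beyond the scatter), so the reading of compound 4 is lower than both halogen values, and both steps lie beyond the scatter.

Steps to compound 1, the methoxy compound, cannot be read, as it stands as "not determined" (no result reported). The compounds shown also leave open whether a larger amine on this carbon, such as methylamino or dimethylamino, would keep the low reading of the plain amino group.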